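Aryl ether swap on the core of compound 3

A few compounds are considered here, and "the series" means these few. Any claim that something is new, unique, unknown or untested is made for them only; others in the source may bear on it.

Compound 3 `C/C(=C\COc1c(Cl)cccc1Cl)CC/C=C(\C)C1=CC(=O)C(C)(C)O1` gives the lowest number of the three measured in a functional assay on MT4 cells (Homo sapiens) for inhibition (a lower number here means a stronger inhibitor, a higher number a weaker inhibitor), at 15.5 ug/mL. Compound 1 `C/C(=C\COc1c(Cl)cccc1Cl)CC/C=C(\C)C1CC(=O)C(C)(C)O1` gives 32.5 ug/mL in this assay, and compound 2 `COc1cccc(OC/C=C(\C)CC/C=C(\C)C2CC(=O)C(C)(C)O2)c1` gives 51.5 ug/mL there. The step of a 2.1-fold lower number from compound 1 to compound 3 (0.32 log units; beyond the scatter) separates compound 3 from its nearest neighbour, and compound 2 stands furthest from compound 3 in this assay.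

Compound 4 `COc1cccc(OC/C=C(\C)CC/C=C(\C)C2=CC(=O)C(C)(C)O2)c1` differs from compound 3 by 3-methoxyphenyl in place of 2,6-dichlorophenyl on an oxygen on a saturated carbon. Among the measured compounds shown here, one measured step bears on this change: the same aryl swap made on the core of compound 1, which gave a 1.6-fold higher number from compound 1 to compound 2 (0.20 log units; within the scatter). That step was small and within the scatter, so in this assay the step from compound 3 to compound 4 is expected to be of similar size, a slight rise in the number or none beyond the scatter, and the expected step is a 1.6-fold higher number from compound 3 to compound 4 (0.21 log units; within the scatter). For the measured compounds named here, no measured step tells whether the aryl swap behaves the same on the core of compound 3 as on the core of compound 1, so the range is kept wide. Compound 4 is therefore estimated at 25 ug/mL in this assay, with a range from 12 ug/mL to 50 ug/mL.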

Compound 4, half-maximal inhibitory concentration: 34 ug/mL
Beside the measured number, compound 4's estimate is 1.4-fold (0.13 log units) below it; the measured number falls inside the stated range.
By their numbers in this assay, from the lowest: compound 3; then compounds 1, 4 and 2 (each within the scatter of the next).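

In this assay, 3-methoxyphenyl in place of 2,6-dichlorophenyl on the oxygen gives a 2.2-fold higher number from compound 3 to compound 4 (0.34 log units; beyond the scatter), so this swap now produces a step beyond the scatter, which the earlier pair on the other core did not, yet the two steps still agree: the same change on two cores in this assay, a 1.6-fold higher number (0.20 log units; within the scatter) from compound 1 to compound 2 and a 2.2-fold higher number (0.34 log units; beyond the scatter) from compound 3 to compound 4, 1.4-fold (0.14 log units) apart, within the scatter of two such steps. The second core change, read on the 3-methoxyphenyl pair, gives a 1.5-fold lower number from compound 2 to compound 4 (0.18 log units; within the scatter), so it stays beyond the scatter only on the 2,6-dichlorophenyl pair, although the two steps do not differ beyond the scatter: the same change on two cores in this assay, a 2.1-fold lower number (0.32 log units; beyond the scatter) from compound 1 to compound 3 and a 1.5-fold lower number (0.18 log units; within the scatter) from compound 2 to compound 4, 1.4-fold (0.14 log units) apart, within the scatter of two such steps. Across these four compounds, the aryl swap and the core change show no dependence on each other that can be told from the scatter, and compound 3, the only compound with steps to all others printed beyond the scatter, is the strongest of the set.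

With only two aryl groups in the series, the compounds shown cannot separate the contribution of the chlorine atoms from that of the methoxy group, and an unsubstituted phenyl on the same oxygen would bear on this. Also open, as far as these compounds go, is how either core responds when a carboxylic acid or an amine replaces the aryl group, or when a longer chain carries it.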